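Compound 2 between two limits, and the thiophene swap

The compounds below may be only part of what the source reports. "The series", "measured", "known", "first", "only" and "open" are said of these compounds alone.

Values so far in a functional assay on U-87MG ATCC cells (Homo sapiens) for antiproliferative activity, with a stated time of 3 days; on this read-out higher numbers stand for an effect only at larger amounts of compound and lower numbers for an effect already at smaller amounts
- compound 1 `Oc1ccc(CN(Cc2ccccc2)Cc2ccc(O)c3ncccc23)c2cccnc12` gives < 0.5 uM (a limit)
- compound 2 `Oc1ccc(CN(Cc2cccc(C(F)(F)F)c2)Cc2ccc(O)c3ncccc23)c2cccnc12` gives 2 uM
- compound 3 `Oc1ccc(CN(Cc2cc(C(F)(F)F)cc(C(F)(F)F)c2)Cc2ccc(O)c3ncccc23)c2cccnc12` gives < 0.2 uM (a limit)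

Among the compounds with values here, compound 2 holds the only exact number of the three, 2 uM. Compound 4 `Oc1ccc(CN(Cc2cccs2)Cc2ccc(O)c3ncccc23)c2cccnc12` has thiophen-2-yl in place of its 3-(trifluoromethyl)phenyl (thiophen-2-yl in place of 3-(trifluoromethyl)phenyl on a saturated chain carbon bound to an amine nitrogen).

Within the data shown here, two measured steps bear on this, each putting trifluoromethyl in place of hydrogen on an aromatic carbon, and their directions disagree. One is an at least 10-fold lower number from compound 2 to compound 3 (1.00 log units; beyond the scatter). The other, an at least 4.0-fold higher number from compound 1 to compound 2 (0.60 log units; beyond the scatter), is the closer guide: compound 4, like compound 1, carries no trifluoromethyl. A lower number is therefore expected in this assay, with an expected 4.0-fold lower number from compound 2 to compound 4 (0.60 log units; beyond the scatter). The estimate for compound 4 is 0.5 uM, within 0.15 uM to 2 uM.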

Compound 4, concentration for half-maximal effect: < 0.2 uM
Compound 4 ended at the assay's limit (the forecaster's own chance of this, stated with the estimate: 40%); at least 2.5-fold (0.39 log units) between middle value and limit.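

Putting thiophen-2-yl in place of 3-(trifluoromethyl)phenyl gives an at least 10-fold lower number from compound 2 to compound 4 (1.00 log units; beyond the scatter), so at this place on a saturated chain carbon bound to an amine nitrogen, a five-membered aromatic ring with sulfur is compatible with a low number in this assay. The value of compound 4 is a limit, not an exact number: the limit of < 0.2 uM in this assay, at which 2 of the 4 values shown sit. Compound 1 also stands at a limit, so the step from compound 1 to compound 4 cannot be read.

Still open, on these data alone, is how a furan-2-yl or pyridin-2-yl ring, or a longer chain carrying the thiophen-2-yl, would behave at this place.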